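The compounds below may be only part of what the source reports. "The series", "measured", "known", "first", "only" and "open" are said of these compounds alone.

Compound 1 `O=C(O)CCN1Cc2ccc(NC(=O)c3ccc(C4CCNCC4)cc3)cc2C1=O` gives 9600 nM in a functional assay on a cell-free system (Platelet, plasma, Homo sapiens) for inhibition; on this read-out lower numbers stand for stronger inhibition and higher numbers for weaker inhibition.
Compound 2 `O=C(O)CCN1Cc2ccc(NC(=O)c3ccc(N4CCNCC4)cc3)cc2C1=O` gives 540 nM in this assay.

For the measured compounds named here, compound 2 holds the lowest of the two numbers measured in this assay; the only measured step, an 18-fold lower number from compound 1 to compound 2 (1.25 log units; beyond the scatter), concerns the group on the aromatic carbon and nothing else. Compound 3 `CC(CC(=O)O)N1Cc2ccc(NC(=O)c3ccc(N4CCNCC4)cc3)cc2C1=O` keeps that piperazin-1-yl group and differs from compound 2 only by methyl in place of hydrogen on a saturated chain carbon bound to an amide-type nitrogen in a ring and a saturated chain carbon, so that 2-carboxyethyl becomes 1-(carboxymethyl)ethyl. Going by the values given here, no measured step touches this chain; the single step in hand alters a different place in the molecule and gives no guide to the size or direction of the present change. Without such a precedent the default expectation is a step of no change at the digits printed from compound 2 to compound 3 (within the scatter), staying within the scatter. Compound 3 is therefore estimated at 540 nM in this assay, with a range from 180 nM to 1600 nM to allow for the absence of any directly comparable measurement.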

Compound 3, half-maximal inhibitory concentration: 3740 nM
Beside the measured number, compound 3's estimate is 6.9-fold (0.84 log units) below it; measured number above the stated range.
By their numbers in this assay, from the lowest: compound 2; then compound 3; then compound 1.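

The 2-carboxyethyl chain is a sensitive place in the series: in this assay, methyl in place of hydrogen on the saturated chain carbon bound to the amide-type nitrogen in a ring gives a 6.9-fold higher number from compound 2 to compound 3 (0.84 log units; beyond the scatter) with the piperazin-1-yl group held fixed. The step from 2-carboxyethyl to 1-(carboxymethyl)ethyl therefore shows that this chain, and not only the group on the aromatic carbon, moves the read-out, in the direction of weaker inhibition. Nothing in hand accounts for this step.

Still open, from the compounds shown here alone, is whether ethyl in place of this methyl, or a longer chain such as 3-carboxypropyl, moves the number the same way, and whether the methyl step holds with piperidin-4-yl on the aromatic carbon. Also open, going by these compounds, is how a methyl ester or primary amide in place of the carboxylic acid would read.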